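The source may hold more compounds than are shown below. What is called first, only, known or untested is meant among the compounds shown, and "the series" means these compounds.

Measured so far in a physicochemical assay for lipophilicity, read by HPLC, at pH 7.5; a higher number here means a more lipophilic compound, a lower number a more polar compound:
- compound 1 `CCOc1ccccc1-c1ccc(-c2nc3cnccc3c(NC(COC)C(N)=O)c2C#N)cc1`: 2.8
- compound 2 `CC[C@@H](Nc1c(C#N)c(-c2ccc(-c3ccccc3C(F)(F)F)cc2)nc2cnccc12)C(N)=O`: 3.1
- compound 3 `CCOc1ccccc1-c1ccc(-c2nc3cnccc3c(NC(CC)CNS(=O)(=O)C3CC3)c2C#N)cc1`: 3.6

Compound 2 stands second highest of the three numbers. Its nearest neighbour is compound 1, lower by an amount within the scatter, so no order between these two can be read; compound 3 sits higher, beyond the scatter. Within the data shown here, the only measured step between compounds that differ in one place is a number 0.80 log units higher from compound 1 to compound 3 (beyond the scatter), and it concerns the group on the nitrogen on the aromatic ring, not the biaryl end of the shared core. It therefore does not bear directly on the change now considered.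

Compound 4 `CC[C@@H](Nc1c(C#N)c(-c2ccc(-c3ccc(Cl)cc3)cc2)nc2cnccc12)C(N)=O` is not yet measured. Relative to compound 2 the change is 4-chlorophenyl in place of 2-(trifluoromethyl)phenyl on an aromatic carbon. Among the measured compounds shown here, no measured step touches that position, so the expectation rests only on the composition of the two groups as counted, and no step beyond the scatter is assumed. The expected step is a number 0.10 log units lower from compound 2 to compound 4 (within the scatter), within the scatter. Compound 4 is estimated at 3, with a range from 2.6 to 3.4.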

Compound 4, distribution coefficient: 3.1
Compound 4: middle estimate off by 0.10 log units, on the low side; measured number inside the range.
By their numbers in this assay, from the lowest: compounds 1, 2 and 4 (each within the scatter of the next); then compound 3.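

In this assay, among these compounds, no change at the digits printed from compound 2 to compound 4 (within the scatter) gives the series its first step at this position, which the earlier compounds left untouched. At this position, on an aromatic carbon, 2-(trifluoromethyl)phenyl and 4-chlorophenyl, which differ in their halogen and in heavy-atom count as well as in where the substituent stands, show no difference beyond the scatter in this pair. Nothing at hand explains this outcome.

On these data alone, the reading rests on one pair with one group on the nitrogen, so whether it holds alongside other groups there remains open. Also open, as far as these compounds go, is how this assay responds when an aryl group at this position carries an amine or a carboxylic acid in place of these halogen-bearing substituents.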